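The source may hold more compounds than are shown below. What is called first, only, known or untested is meant among the compounds shown, and "the series" means these compounds.

Of the compounds shown here, three have so far been tested in a functional assay on the whole organism (plasma, strain Wistar) with Rattus norvegicus as the target, with a stated time of 15 days, at a dose of 10 mg/kg by the oral route; on this read-out lower numbers stand for a weaker effect and higher numbers for a stronger effect at the one dose given. Compound 1 `Cc1nc(COc2ccc(/C=C3\SC(=O)NC3=O)cc2)cs1` gives 10.6%, compound 2 `O=C1NC(=O)/C(=C/c2ccc(OCc3csc(-c4ccccc4)n3)cc2)S1` gives 20.4%, and compound 3 `O=C1NC(=O)/C(=C/c2ccc(OCCSc3nnc(-c4ccc([N+](=O)[O-])cc4)[nH]3)cc2)S1` gives 13.9%. Among the measured compounds shown here, the only pair differing in a single place is compound 1 and compound 2, where a number 9.8 percentage points higher from compound 1 to compound 2 (within the scatter) was seen. Compound 3 stands between the two other numbers, though its gaps to compound 1 and to compound 2 both lie within the scatter, so no ordering among the three can be claimed.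

Compound 4 `COc1ccc(-c2nnc(SCCOc3ccc(/C=C4\SC(=O)NC4=O)cc3)[nH]2)cc1` is the next compound, differing from compound 3 in one place: methoxy in place of nitro on an aromatic carbon. For the measured compounds named here, no measured step concerns this change; the single measured step, from compound 1 to compound 2, is a different change and itself lies within the scatter, so it gives no guide to direction. Without any bearing step, a step beyond the scatter is not expected. For compound 4 the expected step is a number 0.1 percentage points higher from compound 3 to compound 4 (within the scatter). Compound 4 is therefore estimated at 14%, with a range from 4% to 26%.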

Compound 4, a percentage reported as activity, at one dose (the size of the read-out at that dose, not a potency): 33.6%
Estimate against measurement, compound 4: 19.6 percentage points below, outside the stated range (above it).
By their numbers in this assay, from the lowest: compounds 1, 3 and 2 (each within the scatter of the next); then compound 4.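

In this assay, the change from 4-nitrophenyl to 4-methoxyphenyl gives a number 19.7 percentage points higher from compound 3 to compound 4 (beyond the scatter), the only step shown so far that lies beyond the scatter. This shows that a change on an aromatic carbon of the six-membered aromatic ring of carbon only, para to a large group, can move this read-out, which the step between compound 1 and compound 2, at a different place, did not show. Nothing measured here accounts for the step.

With a single pair at this place, compound 3 and compound 4 cannot tell whether the step follows from the loss of nitro or the arrival of methoxy. As far as these compounds go, it remains open how an amine, a carboxylic acid or a chlorine atom at this place would read, and whether methoxy would give a similar step on another core.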